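Propargyl for 4-nitrobenzyl: first read on compound 3

A few compounds are considered here, and "the series" means these few. Any claim that something is new, unique, unknown or untested is made for them only; others in the source may bear on it.

Among the measured compounds shown here, in a functional assay on PC-9 cells (Homo sapiens) for inhibition, read by MTT assay, with a stated time of 72 h (a lower number here means a stronger inhibitor, a higher number a weaker inhibitor), compound 1 `Cc1cc(Nc2cc(-c3ccccc3)[nH]n2)n2nc(SCc3ccc([N+](=O)[O-])cc3)nc2n1` gives 7980 nM, the only actual number so far. Compound 2 `Cc1cc(Nc2ccn(Cc3ccccc3)n2)n2nc(SCc3ccc(Br)cc3)nc2n1` gives only a limit of the assay, > 50000 nM. For the measured compounds named here, no two measured compounds differ in a single place, so compound 1 has no direct measured comparison.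

Compound 3 `C#CCSc1nc2nc(C)cc(Nc3cc(-c4ccccc4)[nH]n3)n2n1` keeps the core of compound 1 and differs in one place: ethynyl in place of 4-nitrophenyl on a saturated chain carbon bound to a sulfur. In short, this is 4-nitrobenzyl to propargyl, with ethynyl in place of 4-nitrophenyl on a saturated chain carbon bound to a sulfur.

Going by the values given here, with no measured single-place step in this assay, the series offers no direct guide to the size of this change. The change removes an aromatic ring from compound 1, which stands at 7980 nM, and a modest weakening is expected rather than a gain. The expected change is a 1.8-fold higher number from compound 1 to compound 3 (0.24 log units; within the scatter), an estimate that carries wide uncertainty. Compound 3 is estimated at 14000 nM, with an expected range of 5000 nM to 45000 nM.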

Compound 3, half-maximal inhibitory concentration: > 50000 nM
Compound 3: only a limit was reported; the forecaster's own chance of this, stated with the estimate: 20%; middle value at least 3.5-fold (0.55 log units) away from the limit.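

In this assay the series now has its first single-place step: 4-nitrobenzyl to propargyl gives an at least 6.2-fold higher number from compound 1 to compound 3 (0.79 log units; beyond the scatter). Compound 3 reads > 50000 nM, which is a limit of the assay and not a number, so at this place, a saturated chain carbon bound to a sulfur, ethynyl does not stand in for 4-nitrophenyl, and the step gives only the smallest possible size of the loss. The full size of the loss stays unread, and the read-out leaves little room to show it: the limit of > 50000 nM in this assay, at which 2 of the 3 values shown sit.

Still open, on these data alone, is whether the loss follows the aromatic ring or the nitro group, which a plain benzyl or a 4-aminobenzyl at this place would separate. A longer chain such as n-butyl, or a chain ending in a carboxylic acid, would show whether any group without an aromatic ring can keep a readable number here.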